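From isopropylcarbonyl to ethylcarbamoyl on a shared core

The source may hold more compounds than are shown below. What is called first, only, known or untested is meant among the compounds shown, and "the series" means these compounds.

Results in a functional assay on KARPAS-299 cells (Homo sapiens) for inhibition, read by CellTiter-Glo, with a stated time of 96 h (on this read-out lower numbers stand for stronger inhibition and higher numbers for weaker inhibition), so far
Compound 1 `Cc1cc(Nc2ncc(Cl)c(Nc3cn(C)nc3S(=O)(=O)C(C)C)n2)c(OC2CC2)cc1C(=O)C(C)C` gives "not determined" (no result reported)
Compound 2 `Cc1cc(Nc2ncc(Cl)c(Nc3cn(C)nc3S(=O)(=O)C(C)C)n2)c(OC(C)C)cc1C1CNC1` gives 60 nM

Compound 1 therefore stands without a single number to start from. Compound 3 `CCNC(=O)c1cc(OC2CC2)c(Nc2ncc(Cl)c(Nc3cn(C)nc3S(=O)(=O)C(C)C)n2)cc1C` has not yet been measured. The change ethylamino in place of isopropyl on a carbonyl carbon puts ethylamino in place of isopropyl on a carbonyl carbon. With no number at its start, this change has no expected step size or direction in this assay beyond the usual scatter. For the measured compounds named here, the only anchor is compound 2 at 60 nM in that read-out. Compound 3 is estimated at 80 nM with an expected range of 20 nM to 320 nM in this test.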

Compound 3, half-maximal inhibitory concentration: 20 nM
Beside the measured number, compound 3's estimate is 4.0-fold (0.60 log units) above it; the measured number falls inside the stated range.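

In this assay compound 1 gives "not determined" (no result reported) and compound 3 gives 20 nM so no step can be read between them. The compounds shown leave open how ethylcarbamoyl compares with isopropylcarbonyl on the shared core, and no supporting data bear on this result.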